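The source may report more compounds than this note shows. Statements on the series, on what has been measured and on what is new or still open speak of the compounds shown alone.

Of the compounds shown here, three sharing one core have been tested in a functional assay on MCF7 cells (Homo sapiens) for cytotoxicity, read by MTT assay, with a stated time of 72 h; a higher number here means a weaker inhibitor, a lower number a stronger inhibitor. Compound 1 `FC(F)(F)c1ccc(CSc2nc(Nc3ccccc3Cl)c3ccccc3n2)cc1` gives only a limit there, > 50000 nM. Compound 2 `COc1ccccc1Nc1nc(SCc2ccc(C(F)(F)F)cc2)nc2ccccc12` likewise gives only a limit, > 50000 nM. Compound 3 `CCOc1ccccc1Nc1nc(SCc2ccc(C(F)(F)F)cc2)nc2ccccc12` also gives only a limit, > 50000 nM. The step that the two limits leave unreadable from compound 1 to compound 2 and the step that the two limits leave unreadable from compound 1 to compound 3 cannot be sized, and the same holds for the step that the two limits leave unreadable from compound 2 to compound 3, since every value sits at the limit of > 50000 nM in this assay, at which 3 of the 3 values shown sit. Compound 3 therefore stands at the limit, alongside the two other compounds.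

Compound 4 `Cc1ccccc1Nc1nc(SCc2ccc(C(F)(F)F)cc2)nc2ccccc12` is the next to be measured. It differs from compound 3 by methyl in place of ethoxy on an aromatic carbon. Among the measured compounds shown here, none of the measured steps gives a readable size, so no direction can be drawn from them; the only indication is that all three compounds remain at the limit. Compound 4 is accordingly expected to give 60000 nM, within 15000 nM to 250000 nM, and the step that the limit leaves unreadable from compound 3 to compound 4 is estimated to stay within the scatter.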

Compound 4, half-maximal inhibitory concentration: 37500 nM
Compound 4: middle estimate off by 1.6-fold (0.20 log units), on the high side, and the stated range covers the measured number.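

Among the compounds shown here, with the methyl group on this aromatic carbon, the 2-methylphenyl compound 4 is the first to give a measured number rather than a limit in this assay. Set against the three earlier compounds, this gives an at least 1.3-fold lower number from compound 3 to compound 4 (0.12 log units; that floor lies within the scatter), an at least 1.3-fold lower number from compound 2 to compound 4 (0.12 log units; that floor lies within the scatter) and an at least 1.3-fold lower number from compound 1 to compound 4 (0.12 log units; that floor lies within the scatter). Each of these is only a floor, and the true size of the steps stays unknown because the other values are all limits: the limit of > 50000 nM in this assay, at which 3 of the 4 values shown sit.

The compounds shown therefore leave open whether methyl truly differs from ethoxy, methoxy or chloro at this position. They also leave open how an amino group, a carboxylic acid or a longer alkyl chain on the same aromatic carbon would read.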